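This account rests on a few compounds, and the source may have more. Where it says the series, first, only, none or still open, it means among the compounds named here.

Working notes on the series. Compound 1 `COc1ccc(C(=O)/C=C\Nc2ccc(-c3nc4cc(OC)c(OC)c(OC)c4s3)cc2C)cc1F` and compound 2 `COc1ccc(C(=O)/C=C\Nc2ccc(-c3nc4cc(OC)c(OC)c(OC)c4s3)cc2C)cc1[N+](=O)[O-]` share one core and differ in a single place. Compound 3 `COc1ccc2nc(-c3ccc(N/C=C\C(=O)c4ccc(OC)c([N+](=O)[O-])c4)cc3)sc2c1` is built on a second core; the difference between the two cores is not broken down here. Compound 4 `COc1ccc2nc(-c3ccc(N/C=C\C(=O)c4ccc(OC)c(F)c4)cc3)sc2c1` stands to compound 3 as compound 1 stands to compound 2.

In a functional assay on MIA PaCa-2 cells (Homo sapiens) for antiproliferative activity, read by sulforhodamine B assay, with a stated time of 48 h (on this read-out lower numbers stand for stronger inhibition and higher numbers for weaker inhibition), compound 1 gives 1800 nM. In this assay compound 2 gives 23400 nM, and compound 3 gives 23600 nM; the numbers for compound 2 and compound 3 lie within the scatter of each other.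

The change from compound 2 to compound 1 is fluoro in place of nitro on an aromatic carbon. Its effect was a 13-fold lower number from compound 2 to compound 1 (1.11 log units; beyond the scatter). Going by the values given here, the change from compound 3 to compound 4 is fluoro in place of nitro on an aromatic carbon; it is the same change at the same place, and it occurs twice in all among the compounds here, so only one measured instance supports it.

Among the compounds with values here, for compound 4 the expectation is a step of similar size, a 9.4-fold lower number from compound 3 to compound 4 (0.97 log units; beyond the scatter), because the one measured instance gave a 13-fold lower number from compound 2 to compound 1 (1.11 log units; beyond the scatter). The different core of compound 3 is the open point, since no measured pair shows how that core responds to this change; the range is widened for that reason. Compound 4 is therefore expected to give about 2500 nM in this assay. The estimate for compound 4 is expected to fall between 800 nM and 9000 nM.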

Compound 4, half-maximal inhibitory concentration: 1300 nM
The estimate for compound 4 lay 1.9-fold (0.28 log units) above the measured number; the measured number falls inside the stated range.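

In this assay, moving from the 4-methoxy-3-nitrophenyl to the 3-fluoro-4-methoxyphenyl group on the second core gives an 18-fold lower number from compound 3 to compound 4 (1.26 log units; beyond the scatter). The size of this step carries across the two cores in this series, with no difference beyond the scatter: the same change on two cores in this assay, a 13-fold lower number (1.11 log units; beyond the scatter) from compound 2 to compound 1 and an 18-fold lower number (1.26 log units; beyond the scatter) from compound 3 to compound 4, 1.4-fold (0.15 log units) apart, within the scatter of two such steps. This agreement rests on two pairs in one assay, so it does not show that the step would hold on a third core or in another cell line, and it does not show which feature of the exchange of nitro for fluoro produces the step.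

The compounds shown leave open how the two cores compare with each other, since no listed pair isolates that difference, and how far the trend extends to other groups at this aromatic carbon. Chloro, nitrile, an amine or plain hydrogen in that place could show whether fluoro is unusual or nitro alone is the poor group, and a hydroxy group in place of the methoxy group could show whether the step depends on that neighbouring substituent.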